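The source may report more compounds than this note shows. Statements on the series, on what has been measured and on what is new or still open speak of the compounds shown alone.

Measured compounds:
- Compound 1, `COc1cc(NC(C)CCCNC(=O)C2CCC3(CC2)OOC2(OO3)C3CC4CC(C3)CC2C4)c2ncccc2c1-c1ccc(C(F)(F)F)cc1`: in an ADME assay on Caco-2 cells (Homo sapiens) for cytotoxicity, read by neutral red uptake, with a stated time of 72 h (a higher number here means that more compound is tolerated, a lower number that less compound is tolerated), compound 1 gives > 50000 nM.
- Compound 2, `COc1cc(NC(C)CCCNCC2CCC3(CC2)OOC2(OO3)C3CC4CC(C3)CC2C4)c2ncccc2c1-c1ccccc1`: in this assay compound 2 is recorded as "not determined" (no result reported).

The value for compound 1 is a limit of the assay and not a number. Of the two values shown, one sits at the limit of > 50000 nM in this assay, at which 1 of the 2 values shown sits, and that one belongs to compound 1. Within the data shown here, compound 2 therefore stands nowhere on a scale of numbers: no measurement of its own is reported, and the only value in the set is the limit reached by compound 1.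

Compound 3, `COc1cc(NC(C)CCCNCC2CCC3(CC2)OOC2(OO3)C3CC4CC(C3)CC2C4)c2ncccc2c1-c1ccc(C)cc1`, differs from compound 2 in one place: methyl in place of hydrogen on an aromatic carbon. No step between measured compounds is shown, so there is no measured change of this kind to lean on. In this assay a change this small is expected to move the read-out by no more than the usual scatter, in no particular direction. Compound 3 is accordingly expected to give about 50000 nM, with a range from 20000 nM to 100000 nM.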

Compound 3, half-maximal cytotoxic concentration: 11700 nM
Beside the measured number, compound 3's estimate is 4.3-fold (0.63 log units) above it, outside the stated range (below it).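

No step can be read from these results: compound 2 has no number in this assay to set against compound 3. The compounds shown leave open whether the change from phenyl to 4-methylphenyl on its own shifts the read-out in this assay. Nothing shown accounts for the value of compound 3.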